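Adding a Methoxy Group to Two Related Aryl Rings

The source may report more compounds than this note shows. Statements on the series, on what has been measured and on what is new or still open speak of the compounds shown alone.

Measured so far in a functional assay on L1210 cells (Mus musculus) for antiproliferative activity, read by MTT assay, with a stated time of 72 h; on this read-out higher numbers stand for weaker inhibition and lower numbers for stronger inhibition:
- compound 1 `COc1cc(C2=NN(C(C)=O)C(c3cc(OC)c(OC)c(OC)c3)O2)cc(OC)c1OC`: > 100000 nM, a limit of the assay rather than a number
- compound 2 `COc1cc(OC)cc(C2OC(c3cc(OC)c(OC)c(OC)c3)=NN2C(C)=O)c1`: 5900 nM
- compound 3 `COc1ccc(C2=NN(C(C)=O)C(c3cccc([N+](=O)[O-])c3)O2)cc1`: 47000 nM

Compound 2 and compound 1 share a core and differ by methoxy in place of hydrogen on an aromatic carbon. That step, an at least 16-fold higher number from compound 2 to compound 1 (1.22 log units; beyond the scatter), reaches (the limit of > 100000 nM in this assay, at which 1 of the 3 values shown sits).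

Compound 4 `COc1ccc(C2=NN(C(C)=O)C(c3ccc(OC)c([N+](=O)[O-])c3)O2)cc1` differs from compound 3 by methoxy in place of hydrogen on an aromatic carbon. The difference between the two cores of compound 3 and compound 2 is not broken down here. The two changes are the same kind of change, not the same: in compound 1 the entering methoxy sits ortho to two methoxy groups, in compound 4 ortho to a nitro group, in both cases para to a large group.

Because an at least 16-fold higher number from compound 2 to compound 1 (1.22 log units; beyond the scatter) weakened inhibition strongly, compound 4 is expected to follow, with a 1.9-fold higher number from compound 3 to compound 4 (0.28 log units; within the scatter). Compound 4 is therefore estimated at 90000 nM, roughly between 30000 nM and 300000 nM.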

Compound 4, half-maximal inhibitory concentration: > 100000 nM
Compound 4 gave a limit, no number (the forecaster's own chance of this, stated with the estimate: 45%); middle value at least 1.1-fold (0.04 log units) away from the limit.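

In this assay, methoxy in place of hydrogen on an aromatic carbon also weakened inhibition on the second core (an at least 2.1-fold higher number from compound 3 to compound 4 (0.32 log units; beyond the scatter)). The direction of the change therefore carried over between these two cores, the only two shown: (the same change on two cores in this assay, an at least 16-fold higher number (1.22 log units; beyond the scatter) from compound 2 to compound 1 and an at least 2.1-fold higher number (0.32 log units; beyond the scatter) from compound 3 to compound 4; the limit leaves it open whether they differ). As far as these compounds go, compound 4 gives a limit of the assay rather than a number, as does compound 1, so the size of the change on each core stays unknown, and these data do not show whether it costs more on one core than on the other: (the limit of > 100000 nM in this assay, at which 2 of the 4 values shown sit).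

The compounds shown leave open how a hydroxyl group, an amine or a fluorine would behave at the same carbon. They also leave open whether a longer chain, such as ethoxy, would follow the methoxy.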